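Furan-3-yl for phenyl in the anilinonitrile series

The compounds below may be only part of what the source reports. "The series", "measured", "known", "first", "only" and "open" are said of these compounds alone.

Measured so far:
compound 1, `CCN(c1cccc(-c2ccccc2)c1)c1ccc(C#N)c(Cl)c1`: "not determined" (no result reported)
compound 2, `N#Cc1ccc(N2CCCc3c(-c4ccncc4)cccc32)cc1C(F)(F)F`: 15000 nM
compound 3, `CCN(c1ccc(C#N)c(Cl)c1)c1cc(-c2ccccc2)ccc1C`: > 30000 nM

Three compounds have been run in a functional assay on CWR22R cells (Homo sapiens) for antiproliferative activity, read by CCK-8 assay, with a stated time of 6 days; on this read-out lower numbers stand for stronger inhibition and higher numbers for weaker inhibition. For compound 1 no result was reported, "not determined" (no result reported). Among the measured compounds shown here, compound 2 gives 15000 nM, the only plain number in the set. Compound 3 returns only a limit of the assay, > 30000 nM, so no number is known for it; it is one of the entries at that limit (the limit of > 30000 nM in this assay, at which 1 of the 3 values shown sits). On the numbers shown, compound 3 therefore stands no better than the edge of what the assay reports, and no pair of measured compounds differs in a single place, so no measured step is available to lean on.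

Compound 4, `CCN(c1ccc(C#N)c(Cl)c1)c1cc(-c2ccoc2)ccc1C`, differs from compound 3 in one place: furan-3-yl in place of phenyl on an aromatic carbon. For the measured compounds named here, with no measured step to calibrate the change and compound 3 at the limit, the step from compound 3 to compound 4 is expected to be a number no higher from compound 3 to compound 4 (the limit leaves the size open), that is, none beyond the usual scatter, in either direction. Compound 4 is expected to give about 30000 nM in this assay, with a range from 10000 nM to 100000 nM, and a fair chance that again only a limit is reported.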

Compound 4, half-maximal inhibitory concentration: > 30000 nM
Compound 4 gave a limit, no number (the forecaster's own chance of this, stated with the estimate: 55%); the middle value sits exactly at the limit.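

Compound 3 and compound 4 both return only a limit of the assay, so no step between them can be read, and the two entries share one edge: the limit of > 30000 nM in this assay, at which 2 of the 4 values shown sit.

The compounds shown leave open whether furan-3-yl in place of phenyl changes the result in this assay in either direction, and by how much.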